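The source may hold more compounds than are shown below. What is called first, only, known or untested is meant among the compounds shown, and "the series" means these compounds.

Measured so far in a functional assay on cells for antagonist activity at C-C chemokine receptor type 4 (Homo sapiens), read by fluorescence and calcium flux, with stated times of 2.5 s and 45 s; a lower number here means a stronger inhibitor, a higher number a weaker inhibitor:
- compound 1, `Cc1nn([C@H](C)c2ccc(Cl)cc2Cl)c2nc(N3CC[C@H](N4CCC[C@H]4C(N)=O)[C@H](C)C3)cnc12`: 170 nM
- compound 2, `Cc1nn(C(C)c2ccc(Cl)cc2Cl)c2nc(N3CCC(N4CCCCC4)C(C)C3)cnc12`: 126 nM
- compound 3, `CC1CN(c2cnc3cnn(C(C)c4ccc(Cl)cc4Cl)c3n2)CCC1N1CCCCC1`: 238 nM

Compound 1 sits in the middle of these three numbers. Its distance to compound 2 and its distance to compound 3 are both within the usual scatter of repeated measurements, so the three compounds cannot be told apart on this assay.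

Among the measured compounds shown here, the only step among the measured compounds is the one from compound 2 to compound 3, where a hydrogen replaces a methyl on an aromatic carbon, and it gave a 1.9-fold higher number from compound 2 to compound 3 (0.28 log units; within the scatter), which is within the scatter.

Compound 4, `Cc1nn([C@H](C)c2ccc(Cl)cc2Cl)c2nc(N3CC[C@H](N4CCC[C@H]4C(=O)O)[C@H](C)C3)cnc12`, differs from compound 1 in one place: hydroxy in place of amino on a carbonyl carbon. For the measured compounds named here, the step from compound 2 to compound 3 touches a different part of the shared core and says nothing about the carbonyl carbon, so no measured step bears on this change. The expectation for compound 4 therefore rests on the value of compound 1 alone, with a wide range to allow for an untested change.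

Compound 4 is estimated at 400 nM in this assay, within a range of 120 nM to 1500 nM. This estimate means a step of a 2.4-fold higher number from compound 1 to compound 4 (0.37 log units; beyond the scatter).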

Compound 4, half-maximal inhibitory concentration: 670 nM
Estimate against measurement, compound 4: 1.7-fold (0.22 log units) below; low and high end bracket the measured number.
By their numbers in this assay, from the lowest: compounds 2, 1 and 3 (each within the scatter of the next); then compound 4.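

Among the compounds shown here, changing 2-carbamoylpyrrolidin-1-yl to 2-carboxypyrrolidin-1-yl gives the first step in these compounds that clears the usual scatter: in this assay there is a 3.9-fold higher number from compound 1 to compound 4 (0.60 log units; beyond the scatter), which points towards a weaker inhibitor. This shows that the assay responds to what sits on this carbonyl carbon, even when the change is only one nitrogen exchanged for one oxygen and the computed counts of hydrogen-bond donors and acceptors and the net charge are the same for amino and hydroxy. No measured evidence on the origin of this step is available, so the data give its size and direction and nothing more.

Still open, going by these compounds, is how other groups on this carbonyl carbon would read, such as methoxy, which would make a methyl ester, or methylamino, which would make an N-methyl amide. Also open, on these data alone, is whether the exchange of amino for hydroxy gives a step of similar size on a core carrying hydrogen in place of the methyl on the aromatic carbon.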